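This account rests on a few compounds, and the source may have more. Where it says the series, first, only, none or still open, it means among the compounds named here.

Measured so far in a functional assay on cells (Neutrophil, Homo sapiens) for inhibition, with a stated time of 10 min; on this read-out higher numbers stand for weaker inhibition and lower numbers for stronger inhibition: compound 1 `CCOC(=O)c1cnn(CC(C)O)c1NC(=O)NCc1ccccc1` gives 15 nM. Compound 2 `CCOC(=O)c1cnn(CC(O)CC)c1NC(=O)NC(C)C` gives a value that is a limit of the assay and not a number, > 10 nM. Compound 3 `CCOC(=O)c1cnn(CC(C)O)c1NC(=O)Nc1ccccc1F` gives 100 nM.

Compound 3 stands highest of the two numbers in this assay; its nearest neighbour is compound 1, and the step of a 6.7-fold higher number from compound 1 to compound 3 (0.82 log units; beyond the scatter) lies beyond the scatter. The one limit in the set is described by the limit of > 10 nM in this assay, at which 1 of the 3 values shown sits.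

Compound 4 `CCOC(=O)c1cnn(CC(C)O)c1NC(=O)NC(C)C` has not been measured. It differs from compound 3 as follows: isopropyl in place of 2-fluorophenyl on an amide-type nitrogen. For the measured compounds named here, compound 2 shares the isopropyl urea with compound 4 and differs from it only in the substituent on the core nitrogen, but no step between those two is computed, and its value is a limit.

Going by the values given here, the only measured step that bears on the change is a 6.7-fold higher number from compound 1 to compound 3 (0.82 log units; beyond the scatter), in which the 2-fluorophenyl appeared and the number rose. Removing the 2-fluorophenyl again in favour of isopropyl is therefore expected to lower the number, by a modest amount, as a 2.5-fold lower number from compound 3 to compound 4 (0.40 log units; beyond the scatter). Compound 4 is estimated at 40 nM, with a range from 10 nM to 200 nM.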

Compound 4, half-maximal inhibitory concentration: 90 nM
The estimate for compound 4 lay 2.3-fold (0.35 log units) below the measured number; the measured number falls inside the stated range.
By their numbers in this assay, from the lowest: compound 1; then compounds 4 and 3 (each within the scatter of the next).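

In this assay, isopropyl in place of 2-fluorophenyl on the amide-type nitrogen gives a 1.1-fold lower number from compound 3 to compound 4 (0.05 log units; within the scatter), so at this position a group with one six-membered aromatic ring and one with no ring read alike. Benzyl stands apart from both, with isopropyl in its place giving a 6.0-fold higher number from compound 1 to compound 4 (0.78 log units; beyond the scatter), which matches the earlier 6.7-fold higher number from compound 1 to compound 3 (0.82 log units; beyond the scatter). Compound 2 carries a limit of the assay and not a number, and its step to compound 4 cannot be read: the limit of > 10 nM in this assay, at which 1 of the 4 values shown sits.

On these data alone, whether the lower number of compound 1 goes with the benzyl as a whole stays open, and a phenyl or a 2-phenylethyl group on the same nitrogen would test this. As far as these compounds go, how far the numbers depend on the ethyl ester of the shared core, as against a carboxylic acid there, also stays open.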